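The compounds below may be only part of what the source reports. "The series", "measured", "known", "first", "only" and "open" are said of these compounds alone.

The series is built around an N-acylated pyrazole carbamoyl motif. Compound 1 `O=C(NCc1ccc(OCc2ccccc2)cc1)n1cccn1` carries the benzyloxybenzyl group directly on an amide nitrogen; in an assay on membranes from brain for binding affinity to Monoacylglycerol lipase ABHD6 (Mus musculus), read by fluorescence, with stated times of 1 h and 30 min (on this read-out lower numbers stand for stronger inhibition and higher numbers for weaker inhibition), compound 1 is recorded as "not determined" (no result reported), so no number stands for it. Compound 2 `Cc1cnn(C(=O)N2CCCCC2)c1` pairs the methylated pyrazole with a plain piperidine, and in this assay compound 2 gives 1100 nM. Compound 3 `Cc1cnn(C(=O)N2CCCN(Cc3ccc(OCc4ccccc4)cc3)CC2)c1` keeps that pyrazole but replaces the piperidine with a homopiperazine bearing the benzyloxybenzyl substituent; in this assay compound 3 gives 9500 nM. Among the two values on hand, compound 3 stands highest, and the gap to compound 2 is beyond the usual scatter, so the larger amine clearly weakens inhibition in this assay.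

Compound 4 `O=C(N1CCCN(Cc2ccc(OCc3ccccc3)cc2)CC1)n1cccn1` is the next variant, differing from compound 3 only by hydrogen in place of methyl on an aromatic carbon. Within the data shown here, no measured pair in this set shows what such a change does. Because compound 3 already sits at 9500 nM, a modest loss is judged more likely than a gain, and the step of a 1.4-fold higher number from compound 3 to compound 4 (0.14 log units; within the scatter) is expected to stay close to the scatter. Compound 4 is therefore estimated at 13000 nM, with a plausible range from 4500 nM to 40000 nM.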

Compound 4, half-maximal inhibitory concentration: 960 nM
Compound 4: the middle estimate sits 14-fold (1.13 log units) above what was measured; measured number below the stated range.
By their numbers in this assay, from the lowest: compounds 4 and 2 (each within the scatter of the next); then compound 3.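

In this assay, among these compounds, the exchange of 4-methyl-1H-pyrazol-1-yl for 1H-pyrazol-1-yl gives a 9.9-fold lower number from compound 3 to compound 4 (1.00 log units; beyond the scatter), the only step here between compounds that differ in one place, and it shows that a single carbon on this aromatic carbon of the five-membered aromatic ring with 2 nitrogen shifts the read-out beyond the scatter, with hydrogen giving the stronger inhibition. The weak number of compound 3 therefore cannot be laid to the homopiperazine bearing the benzyloxybenzyl substituent alone, since compound 4 keeps that whole part and loses only the methyl. Nothing in hand explains why the loss of one methyl carries a step of this size.

The compounds shown leave open whether the methyl has a like effect on the plain piperidine of compound 2, as this step comes from the homopiperazine pair alone. They also leave open how other groups on this aromatic carbon, such as a chlorine atom, a methoxy group or an ethyl chain, would compare with hydrogen and methyl.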